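The compounds below may be only part of what the source reports. "The series", "measured", "known", "first", "only" and "open" are said of these compounds alone.

Values in a functional assay on NCI-H727 cells (Homo sapiens) for antiproliferative activity, with a stated time of 48 h; on this read-out lower numbers stand for stronger inhibition and higher numbers for weaker inhibition:

- compound 1 `CCOC(=O)c1cccc(-c2ccc(N(CC)CC)nn2)c1`: 30000 nM
- compound 2 `CCOC(=O)c1ccc(-c2ccc(N(C)C)nn2)cc1`: > 25000 nM (a limit)
- compound 3 `CCOC(=O)c1ccc(-c2ccc(OCC)nn2)cc1`: > 25000 nM (a limit)

Compound 3 gives no number, only the limit > 25000 nM. Compound 3 sits at the limit of > 25000 nM in this assay, at which 2 of the 3 values shown sit. Another compound shares that limit, so compound 3 cannot be ranked within the series.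

The next compound is compound 4 `CCCCOc1ccc(-c2ccc(C(=O)OCC)cc2)nn1`, in which ethoxy becomes butoxy. The change is ethyl in place of hydrogen on a saturated chain carbon, two bonds along the chain from an oxygen on an aromatic ring, with ethyl in place of hydrogen on a saturated chain carbon, two bonds along the chain from an oxygen on an aromatic ring.

Among the compounds with values here, only one measured step involves this substituent, namely a step that the two limits leave unreadable from compound 2 to compound 3. It replaces dimethylamino with ethoxy, and it offers no size to carry over. Within the data shown here, no measured step covers a longer chain on the oxygen, so the direction of any change remains open.

Among the measured compounds shown here, the expectation therefore rests on the general level of the series, and on compound 1 , which gives 30000 nM as the only true number in this assay. No clear gain or loss is expected, and the estimated step is a number no higher from compound 3 to compound 4 (the limit leaves the size open). A further limit would be no surprise. For compound 4 the expected value is 25000 nM, with an estimated range from 10000 nM to 50000 nM.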

Compound 4, half-maximal inhibitory concentration: > 25000 nM
Compound 4 was reported as a limit; the forecaster's own chance of this, stated with the estimate: 65%; the middle value sits exactly at the limit.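

In this assay compound 4 gives > 25000 nM, a limit and not a number. Its steps from compound 2 and compound 3 cannot be read, and these three compounds stay unranked against one another: the limit of > 25000 nM in this assay, at which 3 of the 4 values shown sit. The compounds shown leave open whether butoxy, ethoxy and dimethylamino differ at all in this assay.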